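Swapping a Dimethylamino for an Acetyl on Compound 1

The source may hold more compounds than are shown below. What is called first, only, known or untested is meant among the compounds shown, and "the series" means these compounds.

Compound 1, `COc1cc(C)cc(-c2c(-c3ccnc(-c4ccc(N(C)C)cc4)c3)cnn2CC#N)c1`, gives 10% in a functional assay on A498 cells (Homo sapiens) for cytotoxicity, read by sulforhodamine B assay, with a stated time of 48 h, tested at 100 nM; a lower number here means a stronger effect, a higher number a weaker effect of the compound at the concentration tested.
Compound 2, `Cc1cc(O)cc(-c2nn(CC#N)cc2-c2ccnc(-c3ccc(Oc4ccccc4)cc3)c2)c1`, gives 84% in this assay.

Compound 1 has the lowest number of the two, and compound 2 stands higher by a margin beyond the usual scatter. Compound 3, `COc1cc(C)cc(-c2c(-c3ccnc(-c4ccc(C(C)=O)cc4)c3)cnn2CC#N)c1`, differs from compound 1 in a single place: acetyl in place of dimethylamino on an aromatic carbon. For the measured compounds named here, no measured pair shows this change, so its effect is not known from these data. In this assay a rise of moderate size, toward a weaker effect, is expected, though a result within the scatter cannot be ruled out. Compound 3 is therefore estimated at 40%, between 10% and 80%. The expected step is a number 30 percentage points higher from compound 1 to compound 3 (beyond the scatter).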

Compound 3, a percentage reported as activity, at one concentration (the size of the read-out at that concentration, not a potency): 65%
Beside the measured number, compound 3's estimate is 25 percentage points below it; low and high end bracket the measured number.
By their numbers in this assay, from the lowest: compound 1; then compound 3; then compound 2.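

Exchanging 4-(dimethylamino)phenyl for 4-acetylphenyl produces a large step in this assay (a number 55 percentage points higher from compound 1 to compound 3 (beyond the scatter)), so the group at this position strongly affects the read-out. The two groups have the same heavy-atom and hydrogen-bond acceptor counts, so those counts alone do not predict the outcome here. Nothing available here accounts for the size of this step. Going by these compounds, it remains open whether a simple amino group or a carboxylic acid at this position would give a number close to that of compound 1 or of compound 3.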